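A few compounds are considered here, and "the series" means these few. Any claim that something is new, unique, unknown or untested is made for them only; others in the source may bear on it.

Of the compounds shown here, two built on the shared core have been measured in an assay on isolated protein (urine) for inhibition of Myeloperoxidase (Homo sapiens), with a stated time of 5 min; a higher number here means a weaker inhibitor, a lower number a stronger inhibitor. Compound 1 `CCCc1c[nH]c2ccc(F)cc12` carries a plain saturated chain; in this assay compound 1 reaches only the limit of > 100 nM. Compound 2 `N#CSCCCc1c[nH]c2ccc(F)cc12` adds a cyanosulfanyl group on a saturated chain carbon, three bonds along the chain from an aromatic carbon, and in this assay compound 2 gives 5 nM. Going by the values given here, compound 2 therefore holds the only plain number so far. The other value is a limit of the assay and belongs to compound 1. Among the compounds with values here, the step of an at least 20-fold lower number from compound 1 to compound 2 (1.30 log units; beyond the scatter) is the single measured step, and it rests on the limit (the limit of > 100 nM in this assay, at which 1 of the 2 values shown sits), so its full size is not known beyond being large.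

Within the data shown here, compound 3 `NC(=O)CCc1c[nH]c2ccc(F)cc12` differs from compound 2 by carbamoyl in place of (cyanosulfanyl)methyl on a saturated chain carbon, two bonds along the chain from an aromatic carbon, so the cyanosulfanyl group that accompanied the one large step is gone. Because the step of an at least 20-fold lower number from compound 1 to compound 2 (1.30 log units; beyond the scatter) shows that adding that group gave a much lower number, removing it is expected to move the number back up by a large step, a 60-fold higher number from compound 2 to compound 3 (1.78 log units; beyond the scatter). Compound 3 is thus estimated at 300 nM, in the range 30 nM to 3000 nM, with a fair chance that only a limit is reported.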

Compound 3, half-maximal inhibitory concentration: 132 nM
The estimate for compound 3 lay 2.3-fold (0.36 log units) above the measured number, within the range that was stated.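

In this assay, putting carbamoyl in place of (cyanosulfanyl)methyl on a saturated chain carbon, two bonds along the chain from an aromatic carbon, gives a 26-fold higher number from compound 2 to compound 3 (1.42 log units; beyond the scatter), so carbamoyl at this place does not keep the low number that goes with the cyanosulfanyl group. Even so, compound 3 gives a plain number of 132 nM, which shows that a chain without the cyanosulfanyl group can still yield a readable value in this assay. Whether carbamoyl improves on the plain chain cannot be told, and the step from compound 1 to compound 3 cannot be read, because compound 1 stands at a limit of the assay and not at a number: the limit of > 100 nM in this assay, at which 1 of the 3 values shown sits.

Compound 3 replaces the whole (cyanosulfanyl)methyl with carbamoyl, so the compounds shown do not separate the loss of the cyanosulfanyl group from the change in the group that ends the chain. On these data alone, it remains open whether a nitrile, a carboxylic acid or an amine at this place, or a longer chain ending in carbamoyl, would give a number closer to that of compound 2 or to that of compound 3.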